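A few compounds are considered here, and "the series" means these few. Any claim that something is new, unique, unknown or untested is made for them only; others in the source may bear on it.

Three compounds have so far been measured in a functional assay on MT4 cells (Homo sapiens); a higher number here means a weaker inhibitor, a lower number a stronger inhibitor:

compound 1 `CCC1(C)OC(/C(C)=C/COc2ccc3ccc(=O)oc3c2)=CC1=N` gives 2.65 ug/mL
compound 2 `C/C(=C\CO)CC1=CC(=O)C(C)(C)O1` gives 3.05 ug/mL
compound 3 `COc1ccccc1C1=CC(=O)CO1` gives 44.4 ug/mL

Compound 3 has the highest number of the three, and its gaps to compound 2 and to compound 1 both lie beyond the usual scatter, so it is the weakest inhibitor of this set.

Compound 4 `O=C1C=C(c2ccccc2)OC1` differs from compound 3 in one place: hydrogen in place of methoxy on an aromatic carbon. Going by the values given here, no pair of measured compounds shares this change, so the data give no direct guide to its effect. Removing a small group from the ring is expected to shift the number little; the step of a 1.4-fold higher number from compound 3 to compound 4 (0.13 log units; within the scatter) is expected to stay within or only slightly beyond the scatter, toward a weaker inhibitor. Compound 4 is therefore estimated at 60 ug/mL, with a range from 20 ug/mL to 180 ug/mL.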

Compound 4, concentration for 50% inhibition: 31.7 ug/mL
Beside the measured number, compound 4's estimate is 1.9-fold (0.28 log units) above it, and the stated range covers the measured number.
By their numbers in this assay, from the lowest: compounds 1 and 2 (each within the scatter of the next); then compounds 4 and 3 (each within the scatter of the next).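

In this assay, replacing the methoxy with hydrogen gives a 1.4-fold lower number from compound 3 to compound 4 (0.15 log units; within the scatter). Going by these compounds alone, this is the first direct comparison in the set, and it shows that the methoxy on this aromatic carbon can be removed without a change that stands clear of the scatter. Compound 3 and compound 4 therefore cannot be told apart here. The information available offers no explanation for this result. The compounds shown leave open whether an amine, a carboxylic acid or a longer chain on this same carbon would move the number beyond the scatter.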